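The compounds below may be only part of what the source reports. "The series", "measured", "known", "first", "only" and "open" are said of these compounds alone.

Of the compounds shown here, two sharing one core have been measured so far. Compound 1 `CC(C)CN(Cc1ccc(C(=O)NO)cc1)S(=O)(=O)c1cc(F)c(F)c(F)c1F` gives 520 nM in a functional assay on MV4-11 cells (Homo sapiens) for inhibition, with a stated time of 72 h (on this read-out lower numbers stand for stronger inhibition and higher numbers for weaker inhibition), and compound 2 `COCCN(Cc1ccc(C(=O)NO)cc1)S(=O)(=O)c1cc(F)c(F)c(F)c1F` gives 660 nM there, which places compound 2 level with compound 1 within the usual scatter. Compound 3 `O=C(NO)c1ccc(CN(C2CCCC2)S(=O)(=O)c2cc(F)c(F)c(F)c2F)cc1` has cyclopentyl in place of 2-methoxyethyl on a sulfonamide nitrogen and still awaits its measurement. Among the compounds with values here, the one measured step that bears on this change, methoxymethyl in place of isopropyl on a saturated chain carbon bound to a sulfonamide nitrogen, is small (a 1.3-fold higher number from compound 1 to compound 2 (0.10 log units; within the scatter)) and stays within the scatter. A single step is thin evidence, and neither measured compound carries a ring on that nitrogen. Even so, no step beyond the scatter is expected in this assay, in either direction. The expected step is small (a 1.3-fold lower number from compound 2 to compound 3 (0.12 log units; within the scatter)) and remains an estimate. For compound 3 the estimated value is 500 nM (expected range 180 nM to 1400 nM).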

Compound 3, half-maximal inhibitory concentration: 2710 nM
Estimate against measurement, compound 3: 5.4-fold (0.73 log units) below, and the stated range ends below it.
By their numbers in this assay, from the lowest: compounds 1 and 2 (each within the scatter of the next); then compound 3.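

In this assay, the group on the sulfonamide nitrogen now makes a difference beyond the scatter, which compound 1 and compound 2 had not shown. Cyclopentyl in place of 2-methoxyethyl gives a 4.1-fold higher number from compound 2 to compound 3 (0.61 log units; beyond the scatter) and cyclopentyl in place of isobutyl gives a 5.2-fold higher number from compound 1 to compound 3 (0.72 log units; beyond the scatter) in the same direction, so compound 3 stands apart from two open-chain compounds that are level with each other. No measured evidence bears on why the cyclopentyl compound inhibits more weakly.

With a single ring at this position, the compounds shown leave open whether the ring itself goes with the weaker inhibition or whether this holds only for cyclopentyl. A cyclopropyl or cyclohexyl group on the same nitrogen, or a chain bearing an amine, could still fall on either side of these values.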